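The source may report more compounds than this note shows. Statements on the series, on what has been measured and on what is new or still open speak of the compounds shown alone.

Of the compounds shown here, three have so far been measured in a functional assay for inhibition, with Homo sapiens as the target; on this read-out lower numbers stand for stronger inhibition and higher numbers for weaker inhibition. Compound 1 `C=CCn1ncc2cnc(Cc3ccccc3)n2c1=O` gives in this assay only a limit, > 48000 nM. Compound 2 `C=CCn1nc(CCC)c2c(C)nc(CCC)n2c1=O` gives 29000 nM in this assay, and compound 3 `CCCc1nn(C)c(=O)n2c(CCC)nc(C)c12` gives 18000 nM. Compound 2 and compound 3 differ in a single place: hydrogen in place of vinyl on a saturated chain carbon bound to an aromatic nitrogen. That change made a step of a 1.6-fold lower number from compound 2 to compound 3 (0.21 log units; within the scatter), so the two values cannot be told apart with confidence. Compound 4 `Cn1ncc2cnc(Cc3ccccc3)n2c1=O` has not yet been measured. It arises from compound 1 by the same change, (hydrogen in place of vinyl on a saturated chain carbon bound to an aromatic nitrogen), at a place described in the same words. The difference between the core of compound 1 and the core of compound 2 is not broken down here. For compound 1 the starting point is itself uncertain, since its value sits at the limit of > 48000 nM in this assay, at which 1 of the 3 values shown sits. Going by the step from compound 2 to compound 3, the expected step is a step that the limit leaves unreadable from compound 1 to compound 4. Compound 4 is therefore estimated at 60000 nM in this assay, most likely between 20000 nM and 200000 nM, and quite possibly again reported only as a limit.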

Compound 4, half-maximal inhibitory concentration: > 48000 nM
Compound 4: a limit, no number (the forecaster's own chance of this, stated with the estimate: 70%); the middle value is on the limit's open side.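

In this assay, among these compounds, compound 4, like compound 1, gives only a limit and not a number, so no step between the two can be read: the limit of > 48000 nM in this assay, at which 2 of the 4 values shown sit.

The compounds shown leave open how strongly compound 1 and compound 4 inhibit, and whether the change from allyl to methyl on this core makes any difference.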